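This account rests on a few compounds, and the source may have more. Where it says the series, first, only, none or still open, it means among the compounds named here.

Series notes, inhibition of endoplasmic reticulum aminopeptidase 1.

Compound 1 `O=C(NC1(C(=O)O)CCCCC1)c1cccc2cc(-c3ccc(Cl)cc3)oc12` gives 120 nM in an assay on isolated protein for inhibition of endoplasmic reticulum aminopeptidase 1 (Homo sapiens), with stated times of 15 min and 20 min; on this read-out higher numbers stand for weaker inhibition and lower numbers for stronger inhibition. Among the measured compounds shown here, compound 2 `O=C(NC1(C(=O)O)CCCCC1)c1cccc2c(Br)c(-c3ccc(Cl)cc3)oc12` gives 151 nM in the same assay; the single one-place step so far, a 1.3-fold higher number from compound 1 to compound 2 (0.10 log units; within the scatter), comes from bromo in place of hydrogen on an aromatic carbon. Compound 3 `CC(C)(NC(=O)c1cc(F)cc2cc(-c3ccc(Cl)cc3)oc12)c1nnn[nH]1` gives 275 nM and so carries the highest of the three numbers: its gap to compound 2 stays within the scatter, while its gap to compound 1 lies beyond it, so compound 3 inhibits less strongly than compound 1 only.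

Compound 4 `CC(C)(NC(=O)c1cc(F)cc2cc(-c3ccc(Cl)cc3)oc12)C(N)=O` is the next compound awaiting measurement. It differs from compound 3 by carbamoyl in place of 1H-tetrazol-5-yl on a saturated chain carbon bound to an amide-type nitrogen and two saturated chain carbons.

For the measured compounds named here, no measured step touches this part of the molecule; the only step in hand concerns an aromatic carbon on the core and says nothing about the 1H-tetrazol-5-yl to carbamoyl exchange. The expectation for compound 4 therefore rests on the value of compound 3 alone, widened generously in both directions, and the number is expected to come out somewhat higher, a 2.2-fold higher number from compound 3 to compound 4 (0.34 log units; beyond the scatter), though a result within the scatter cannot be excluded. Compound 4 is accordingly estimated at 600 nM, with a range from 200 nM to 2000 nM.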

Compound 4, half-maximal inhibitory concentration: > 10000 nM
Compound 4: a limit, no number (the forecaster's own chance of this, stated with the estimate: 10%); middle value at least 16-fold (1.22 log units) from the limit.
By their numbers in this assay, from the lowest: compounds 1, 2 and 3 (each within the scatter of the next, the first and the last beyond it). At a limit, above all of these: compound 4.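

Carbamoyl in place of 1H-tetrazol-5-yl on a saturated chain carbon bound to an amide-type nitrogen and two saturated chain carbons gives an at least 36-fold higher number from compound 3 to compound 4 (1.56 log units; beyond the scatter) in this assay, the first large step in the series. The value of compound 4, > 10000 nM, is a limit of the assay and not a number, so the step gives only a minimum size for the change: the limit of > 10000 nM in this assay, at which 1 of the 4 values shown sits. Among the compounds shown here, the only other one-place step, on an aromatic carbon, is a 1.3-fold higher number from compound 1 to compound 2 (0.10 log units; within the scatter) and stays within the scatter, so this chain carbon is the first place at which the series is seen to respond strongly, and here carbamoyl does not stand in for 1H-tetrazol-5-yl.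

Whether inhibition at this place depends on the tetrazole ring itself stays open, since the compounds shown do not tell how a nitrile, a hydroxymethyl, a methyl ester or another five-membered aromatic ring would behave on the same carbon. Compound 1 and compound 3 differ in more than one place, so the carboxylic acid of compound 1 cannot be set directly against the 1H-tetrazol-5-yl of compound 3.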